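Chain extension on a sulfonate ester urea

The source may report more compounds than this note shows. Statements on the series, on what has been measured and on what is new or still open speak of the compounds shown alone.

Three compounds share one core and were tested in a functional assay on MCF7 cells (Homo sapiens) for antiproliferative activity, read by sulforhodamine B assay, with a stated time of 48 h; on this read-out lower numbers stand for stronger inhibition and higher numbers for weaker inhibition. Compound 1 `CC(C)C(=O)Nc1ccc(S(=O)(=O)Oc2ccccc2C(C)C)cc1` gives 8600 nM, compound 2 `CC(C)c1ccccc1OS(=O)(=O)c1ccc(NC(=O)CCl)cc1` gives 2900 nM, and compound 3 `CCCNC(=O)Nc1ccc(S(=O)(=O)Oc2ccccc2C(C)C)cc1` gives 2700 nM. Compound 3 stands lowest of the three numbers, but its gap to compound 2 lies within the scatter, so the two cannot be ordered; the steps of a 3.0-fold lower number from compound 1 to compound 2 (0.47 log units; beyond the scatter) and a 3.2-fold lower number from compound 1 to compound 3 (0.50 log units; beyond the scatter) are both modest, and a 1.1-fold lower number from compound 2 to compound 3 (0.03 log units; within the scatter) is within the scatter.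

Compound 4 `CCCCCNC(=O)Nc1ccc(S(=O)(=O)Oc2ccccc2C(C)C)cc1` differs from compound 3 by ethyl in place of hydrogen on a saturated chain carbon, three bonds along the chain from an amide-type nitrogen. None of the three measured steps touches this part of the molecule: each of them changes the group on the carbonyl carbon, whereas here the propylamino chain of compound 3 is lengthened at its far end. Going by the values given here, there is thus no measured step that bears directly on the change, and the expectation rests on the observation that compound 3 and compound 2, whose carbonyl substituents differ, sit together within the scatter. Compound 4 is therefore expected to show a 1.1-fold lower number from compound 3 to compound 4 (0.03 log units; within the scatter), no step beyond the scatter. The estimate for compound 4 in this assay is 2500 nM, with a range from 900 nM to 7000 nM.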

Compound 4, half-maximal inhibitory concentration: 4000 nM
The estimate for compound 4 lay 1.6-fold (0.20 log units) below the measured number; the measured number falls inside the stated range.
By their numbers in this assay, from the lowest: compounds 3, 2 and 4 (each within the scatter of the next); then compound 1.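

In this assay, going by these compounds alone, ethyl in place of hydrogen on a saturated chain carbon, three bonds along the chain from an amide-type nitrogen, gives the first measured step at this position (a 1.5-fold higher number from compound 3 to compound 4 (0.17 log units; within the scatter)), so lengthening the propylamino chain to pentylamino produces no change that can be told from the scatter. The pentylamino group likewise cannot be separated from chloromethyl on the carbonyl carbon (a 1.4-fold higher number from compound 2 to compound 4 (0.14 log units; within the scatter)), while the gap to isopropyl at that place remains beyond the scatter and modest (a 2.2-fold lower number from compound 1 to compound 4 (0.33 log units; beyond the scatter)), which shows that the separation from compound 1 seen with propylamino also holds for pentylamino. Nothing available here accounts for these results.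

Going by these compounds, whether a chain longer than pentyl, or a chain ending in an amine or a carboxylic acid, would move the number beyond the scatter remains open. All the compounds shown also keep the rest of the shared core the same, so they say nothing about how the chain changes would behave with, for example, a methyl or a chlorine in place of the isopropyl on the sulfonate ester side.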